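A few compounds are considered here, and "the series" means these few. Any claim that something is new, unique, unknown or untested is made for them only; others in the source may bear on it.

Working notes on the series. In an ADME assay for permeability, using PAMPA (on this read-out higher numbers stand for higher permeability and lower numbers for lower permeability), compound 1 `O=C(Nc1cccc(-c2nc3ccccc3s2)c1)c1cnccc1Cl` gives 732 10^-6 cm/s, compound 2 `O=C(Nc1cccc(-c2nc3ccccc3s2)c1)c1ccc(Cl)nc1Cl` gives 104 10^-6 cm/s and compound 3 `Cc1ccc(-c2nc3ccccc3s2)cc1NC(=O)c1cnccc1Cl` gives 791 10^-6 cm/s. Compound 3 and compound 1 fall within the scatter of each other (a 1.1-fold higher number from compound 1 to compound 3 (0.03 log units; within the scatter)), while compound 2 stands clearly apart (a 7.0-fold lower number from compound 1 to compound 2 (0.85 log units; beyond the scatter)). Compound 4 `COc1ccc(-c2nc3ccccc3s2)cc1NC(=O)c1cnccc1Cl` differs from compound 3 by methoxy in place of methyl on an aromatic carbon. The step that bears on this change is the one at the same carbon, a 1.1-fold higher number from compound 1 to compound 3 (0.03 log units; within the scatter), which stayed within the scatter; the move to compound 2 changed a different part of the shared core. No step beyond the scatter is therefore expected in this assay for compound 4, and the estimated step is a 1.2-fold lower number from compound 3 to compound 4 (0.09 log units; within the scatter). Compound 4 is expected to give 650 10^-6 cm/s, with a range of 330 10^-6 cm/s to 1000 10^-6 cm/s.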

Compound 4, apparent permeability: 121 10^-6 cm/s
Estimate against measurement, compound 4: 5.4-fold (0.73 log units) above; the measured number lies below the stated range.
By their numbers in this assay, from the lowest: compounds 2 and 4 (each within the scatter of the next); then compounds 1 and 3 (each within the scatter of the next).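

In this assay, the aromatic carbon ortho to a large group proves sensitive to what sits on it: methoxy in place of methyl gives a 6.5-fold lower number from compound 3 to compound 4 (0.82 log units; beyond the scatter), and methoxy in place of hydrogen gives a 6.0-fold lower number from compound 1 to compound 4 (0.78 log units; beyond the scatter). Methyl at this carbon had stayed within the scatter of hydrogen, whereas methoxy does not. No measurement at hand accounts for this difference.

From the compounds shown here alone, whether the step follows the oxygen or the larger group remains open; ethyl or hydroxy at this carbon would bear on that. Also open, going by these compounds, is whether methoxy gives a similar step with 2,6-dichloropyridin-3-yl on the carbonyl carbon.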